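Cyclohexyl to phenyl at the ring-nitrogen substituent

A few compounds are considered here, and "the series" means these few. Any claim that something is new, unique, unknown or untested is made for them only; others in the source may bear on it.

Three members of the series have numbers in a functional assay on PC-3 cells (Homo sapiens) for antiproliferative activity, read by MTT assay, with a stated time of 72 h; a lower number here means a stronger inhibitor, a higher number a weaker inhibitor. Compound 1 `CCCSc1nc(Cl)c2c(n1)N(Cc1ccccc1)C(C(=O)N1CCN(C(=O)OC(C)(C)C)CC1)N2` gives 47100 nM in this assay. Compound 2 `CCCSc1nc(Cl)c2c(n1)N(Cc1cccs1)C(C(=O)N1CCN(C)CC1)N2` gives 5020 nM. Compound 3 `CCCSc1nc(Cl)c2c(n1)N(CC1CCCCC1)C(C(=O)N1CCN(C)CC1)N2` gives 12800 nM, the second highest of the three and beyond the scatter from both others: compound 2 is nearest with the lower number, compound 1 furthest with the higher one.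

The step under consideration goes from compound 3 to compound 4 `CCCSc1nc(Cl)c2c(n1)N(Cc1ccccc1)C(C(=O)N1CCN(C)CC1)N2`: phenyl in place of cyclohexyl on a saturated chain carbon bound to a nitrogen on an aromatic ring in a ring. Among the measured compounds shown here, one measured step bears on the same position: a 2.5-fold higher number from compound 2 to compound 3 (0.41 log units; beyond the scatter), where a six-membered aromatic ring gave way to the six-membered non-aromatic ring. The present step runs the other way, non-aromatic ring to aromatic ring, so a lowering of roughly that size is expected. For the measured compounds named here, compound 1 also carries the benzyl group but differs from compound 4 at a second place as well; no step between them is in hand, and its value shows only that one benzyl member of the series sits well above compound 3.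

Compound 4 is therefore expected at 6000 nM, with a range of 2500 nM to 15000 nM, which means an expected step of a 2.1-fold lower number from compound 3 to compound 4 (0.33 log units; beyond the scatter). That would place it close to compound 2.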

Compound 4, half-maximal inhibitory concentration: 29800 nM
The estimate for compound 4 lay 5.0-fold (0.70 log units) below the measured number, and the stated range ends below it.
By their numbers in this assay, from the lowest: compound 2; then compound 3; then compounds 4 and 1 (each within the scatter of the next).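

In this assay, the position does not sort by aromatic against non-aromatic ring: a 2.5-fold higher number from compound 2 to compound 3 (0.41 log units; beyond the scatter) and a 2.3-fold higher number from compound 3 to compound 4 (0.37 log units; beyond the scatter) place the cyclohexyl member of the series between the two members with aromatic rings. The two aromatic groups themselves are well separated, with a 5.9-fold higher number from compound 2 to compound 4 (0.77 log units; beyond the scatter) for phenyl in place of thiophen-2-yl, so the identity of the aromatic ring matters at this position at least as much as the presence of one. With the benzyl group held fixed, methyl in place of tert-butoxycarbonyl on the amine nitrogen in a ring gives a 1.6-fold lower number from compound 1 to compound 4 (0.20 log units; within the scatter), so these two groups are not told apart here, and the high number of compound 1 goes with the benzyl group as much as with its tert-butoxycarbonyl. No measurement at hand offers a reason for any of these steps.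

Open, as far as these compounds go, is whether the low number of compound 2 belongs to thiophen-2-yl alone or would extend to a furan-2-yl or pyridin-2-yl ring at the same place. Also open, from the compounds shown here alone, is whether a free amine on that ring nitrogen, or tert-butoxycarbonyl alongside thiophen-2-yl, would behave as the benzyl pair does.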